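Naphthalenyl for methoxyphenyl in a spirooxindole-pyrazole series

A few compounds are considered here, and "the series" means these few. Any claim that something is new, unique, unknown or untested is made for them only; others in the source may bear on it.

Measured so far:
compound 1 `COc1ccc(-c2cc(-c3ccc(Cl)cc3)n(C3C(=O)Nc4ccc(Br)cc43)n2)cc1` — 28700 nM in a functional assay on cells (Cancer cell lines, Homo sapiens) for cytotoxicity, read by sulforhodamine B assay, with a stated time of 48 h; on this read-out higher numbers stand for weaker inhibition of growth and lower numbers for stronger inhibition of growth
compound 2 `COc1ccc(-c2cc(-c3ccc(Cl)cc3)n(C3C(=O)Nc4ccc(Cl)cc43)n2)cc1` — 14700 nM in this assay

Compound 1 carries the highest of the two numbers; its nearest neighbour is compound 2, and the step of a 2.0-fold lower number from compound 1 to compound 2 (0.29 log units; within the scatter) stays within the scatter. Compound 3 `O=C1Nc2ccc(Br)cc2C1n1nc(-c2ccc3ccccc3c2)cc1-c1ccc(Cl)cc1` differs from compound 1 by naphthalen-2-yl in place of 4-methoxyphenyl on an aromatic carbon. Among the compounds with values here, no measured step touches that aryl position; the single known step concerns only the halogen on the shared core and is itself within the scatter, so it gives no direction for the change. The expected step of a 1.1-fold lower number from compound 1 to compound 3 (0.06 log units; within the scatter) is therefore put near zero with a wide range. For compound 3 the estimate in this assay is 25000 nM, between 8000 nM and 80000 nM.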

Compound 3, concentration for total growth inhibition: 9850 nM
The estimate for compound 3 lay 2.5-fold (0.40 log units) above the measured number; low and high end bracket the measured number.
By their numbers in this assay, from the lowest: compounds 3, 2 and 1 (each within the scatter of the next, the first and the last beyond it).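

Within the data shown here, at the aromatic carbon of the five-membered ring, naphthalen-2-yl in place of 4-methoxyphenyl gives a 2.9-fold lower number from compound 1 to compound 3 (0.46 log units; beyond the scatter) in this assay and is the first step beyond the scatter. This position therefore moves the read-out, and compound 3 reaches its number without the hydrogen-bond acceptor of 4-methoxyphenyl. No measured evidence speaks to what lies behind the step. Open, from the compounds shown here alone, is whether the second aromatic ring or the loss of methoxy carries the step, which an unsubstituted phenyl or a 4-aminophenyl group could help separate. Also open, going by these compounds, is whether the step holds on the chloro core of compound 2.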